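Moving the nitro group within a sulfonate ester

A few compounds are considered here, and "the series" means these few. Any claim that something is new, unique, unknown or untested is made for them only; others in the source may bear on it.

Two compounds share one core and differ only in the group carried by a sulfonyl sulfur. Compound 1 `Cc1ccc(S(=O)(=O)Oc2ccc3c(CSc4nc5ccccc5c(=O)[nH]4)cc(=O)oc3c2)cc1` carries a methyl-bearing aromatic ring there, and in an ADME assay on Vero cells (Chlorocebus sabaeus) for cytotoxicity, read by polymerase chain reaction, with a stated time of 18 h (a higher number here means that more compound is tolerated, a lower number that less compound is tolerated), compound 1 gives 117000 nM. Compound 2 `O=c1cc(CSc2nc3ccccc3c(=O)[nH]2)c2ccc(OS(=O)(=O)c3ccc([N+](=O)[O-])cc3)cc2o1` carries a nitro group in place of the methyl, and in this assay compound 2 gives 117000 nM. For the measured compounds named here, the only measured step, no change at the digits printed from compound 1 to compound 2 (within the scatter), shows that swapping methyl for nitro left tolerance unchanged, so compound 2 stands level with compound 1.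

Compound 3 `O=c1cc(CSc2nc3ccccc3c(=O)[nH]2)c2ccc(OS(=O)(=O)c3ccccc3[N+](=O)[O-])cc2o1` keeps the nitro group but moves it: 2-nitrophenyl in place of 4-nitrophenyl on a sulfonyl sulfur. The two structures contain the same atoms, joined differently, and read one bond further out the change is (4-nitrophenyl)sulfonyl to (2-nitrophenyl)sulfonyl.

Going by the values given here, no measured step relocates a group on this ring, so the closest guide is no change at the digits printed from compound 1 to compound 2 (within the scatter), which was flat. A shift no larger than the scatter is therefore expected, written as no change at the digits printed from compound 2 to compound 3 (within the scatter). Compound 3 is expected to give 117000 nM in this assay, within a range from 58000 nM to 234000 nM.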

Compound 3, half-maximal cytotoxic concentration: 144000 nM
Beside the measured number, compound 3's estimate is 1.2-fold (0.09 log units) below it; the measured number falls inside the stated range.
By their numbers in this assay, from the lowest: compounds 1, 2 and 3 (each within the scatter of the next).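

Moving the nitro group on the ring carried by the sulfonyl sulfur gives a 1.2-fold higher number from compound 2 to compound 3 (0.09 log units; within the scatter) in this assay, so this position now looks flat for where the nitro group sits as well as for which group is present: 2-nitrophenyl and 4-nitrophenyl cannot be told apart in this measurement. Changing the group and its place in a single step, 2-nitrophenyl in place of 4-methylphenyl, gives a 1.2-fold higher number from compound 1 to compound 3 (0.09 log units; within the scatter) and also stays within the usual scatter, so the three aromatic sulfonyl groups shown cannot be ranked. No measurement is available that would explain why these numbers stay so close.

From the compounds shown here alone, all three compounds keep a nitro- or methyl-substituted phenyl ring on the sulfonyl sulfur, so it remains open whether the same picture would hold for a ring carrying an amine or a carboxylic acid, or for a plain alkyl chain in place of the ring. The shared core is also the same throughout, which leaves open how much of the tolerance seen in this assay depends on the core rather than on the sulfonyl group.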